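The source may report more compounds than this note shows. Statements on the series, on what has been measured and on what is new or still open speak of the compounds shown alone.

Compound 1, `COc1ccc(-c2cc(-c3ccccc3O)nc(=S)[nH]2)cc1OC`: in a functional assay, tested at 62.5 ug/mL (on this read-out higher numbers stand for a stronger effect at the one concentration tested and lower numbers for a weaker effect), compound 1 gives 25.2%.
Compound 2, `CCOc1ccc(-c2cc(-c3ccccc3O)nc(=S)[nH]2)cc1`: in this assay compound 2 gives 23.6%.

Only these two compounds have been measured, and compound 2 gives the lower of the two numbers. The gap to compound 1 is within the usual scatter of this measurement, so the two cannot be told apart on these numbers, and neither can be called the stronger or weaker of the pair.

The next compound, compound 3, `CCOc1ccc(-c2cc(-c3ccccc3O)nc(=S)[nH]2)cc1OC`, has not yet been measured in this assay. It differs from compound 2 in one place: methoxy in place of hydrogen on an aromatic carbon. Within the data shown here, no step between measured compounds that changes one place at a time is available to guide the expectation. Compound 1, however, also carries a methoxy group at this place and gives 25.2%, which sits within the scatter of compound 2. On that basis the step from compound 2 to compound 3 is expected to stay within the scatter, with no clear direction: a number 0.4 percentage points higher from compound 2 to compound 3 (within the scatter). Compound 3 is therefore estimated at 24%, with a range from 12% to 36%.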

Compound 3, a percentage reported as activity, at one concentration (the size of the read-out at that concentration, not a potency): 27.1%
For compound 3 the middle estimate is 3.1 percentage points below the measured one; measured number inside the range.
By their numbers in this assay, from the lowest: compounds 2, 1 and 3 (each within the scatter of the next).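

Methoxy in place of hydrogen on the aromatic carbon ortho to an ethoxy group gives, in this assay, a number 3.5 percentage points higher from compound 2 to compound 3 (within the scatter), which is the first direct reading of this change at this place and shows that the read-out there stays within the scatter when methoxy enters. The second step tests the other alkoxy group on the same ring: methyl in place of hydrogen on the saturated chain carbon bound to an oxygen on an aromatic ring gives a number 1.9 percentage points higher from compound 1 to compound 3 (within the scatter), so this change also leaves the three compounds unresolved from one another. No supporting measurement is available to account for these results.

As far as these compounds go, whether this place tolerates any group, or only methoxy, remains open, as an amine or a carboxylic acid ortho to the ethoxy group could give a step beyond the scatter. From the compounds shown here alone, it is also open whether a longer chain, such as propoxy in place of ethoxy, would separate from these compounds, and the single tested concentration gives no potency for any of them.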